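This account rests on a few compounds, and the source may have more. Where it says the series, first, only, none or still open, it means among the compounds named here.

Series notes. In an ADME assay on Vero cells (Chlorocebus sabaeus) for cytotoxicity, with a stated time of 5 days (a higher number here means a weaker inhibitor, a lower number a stronger inhibitor), compound 1 `c1csc(C2=NNC(c3ccc(N4CCCCC4)cc3)C2)c1` gives 3200 nM. Compound 2 `Cc1csc(C2=NNC(c3ccc(N4CCCCC4)cc3)C2)c1` gives 31600 nM and compound 3 `Clc1ccsc1C1=NNC(c2ccc(N3CCCCC3)cc2)C1` gives 31600 nM. In this assay compound 3 stands level with compound 2, the pair holding the highest numbers of the three: the step of no change at the digits printed from compound 2 to compound 3 (within the scatter) lies within the scatter, while the step of a 9.9-fold higher number from compound 1 to compound 3 (0.99 log units; beyond the scatter) is the widest gap seen. Compound 4 `Clc1ccc(C2=NNC(c3ccc(N4CCCCC4)cc3)C2)s1` differs from compound 3 by 5-chlorothiophen-2-yl in place of 3-chlorothiophen-2-yl on a carbon with a double bond to nitrogen. Among the compounds with values here, the steps that bear on this are a 9.9-fold higher number from compound 1 to compound 3 (0.99 log units; beyond the scatter) and a 9.9-fold higher number from compound 1 to compound 2 (0.99 log units; beyond the scatter), both of which add a group to the ring of compound 1; no measured step relocates a chloro already present, and the one comparison between differently substituted rings showed no change. The expected step is therefore a 1.1-fold lower number from compound 3 to compound 4 (0.05 log units; within the scatter), within the scatter. Compound 4 is estimated at 28000 nM, range 9000 nM to 70000 nM.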

Compound 4, half-maximal inhibitory concentration: > 100000 nM
Compound 4: a limit, no number; the forecaster's own chance of this, stated with the estimate: 15%; at least 3.5-fold (0.55 log units) between middle value and limit.
By their numbers in this assay, from the lowest: compound 1; then compounds 2 and 3 (each within the scatter of the next). At a limit, above all of these: compound 4.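

The reading for compound 4 in this assay is a limit and not a number: the limit of > 100000 nM in this assay, at which 1 of the 4 values shown sits. Within the data shown here, with the same atoms joined differently, 5-chlorothiophen-2-yl in place of 3-chlorothiophen-2-yl gives an at least 3.1-fold higher number from compound 3 to compound 4 (0.50 log units; beyond the scatter), so where the chloro sits on this ring matters, which no earlier step could show. The other two steps are an at least 3.1-fold higher number from compound 2 to compound 4 (0.50 log units; beyond the scatter) and an at least 31-fold higher number from compound 1 to compound 4 (1.49 log units; beyond the scatter).

The limit leaves the true size of all three steps open. Also open, from the compounds shown here alone, is whether an amine or a carboxylic acid in place of the chloro of 5-chlorothiophen-2-yl would keep the number this high.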